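Thioester variant of a dihydropyrimidinone: expected binding shift

The source may report more compounds than this note shows. Statements on the series, on what has been measured and on what is new or still open speak of the compounds shown alone.

Measured compounds:
Compound 1, `CC1=C(C(=O)OC(C)(C)C)C(c2cccs2)NC(=O)N1` — 26%
Compound 2, `CC1=C(C(=O)CC(C)C)C(c2cccs2)NC(=O)N1` — 19%
Compound 3, `CCNC(=O)C1=C(C)NC(=O)NC1c1cccs1` — 1%

Three compounds share one core and differ only in the group on the carbonyl carbon. In an assay on membranes from CHO cells for displacement of a labelled ligand from adenosine receptor A1 (Homo sapiens), read by scintillation counting, with a stated time of 60 min, tested at 1 uM (on this read-out lower numbers stand for less inhibition and higher numbers for more inhibition at the one concentration tested (going by the name of the read-out)), compound 1 gives 26% and compound 2 gives 19%; the step of a number 7 percentage points lower from compound 1 to compound 2 (within the scatter) lies within the scatter. Compound 3 gives 1% and stands lowest of the three, separated from both others beyond the scatter: a number 25 percentage points lower from compound 1 to compound 3 (beyond the scatter) and a number 18 percentage points lower from compound 2 to compound 3 (beyond the scatter).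

Compound 4, `CC1=C(C(=O)SC(C)C)C(c2cccs2)NC(=O)N1`, is not yet measured. It differs from compound 3 by isopropylsulfanyl in place of ethylamino on a carbonyl carbon. Among the compounds with values here, the steps that bear on this change are those leading into compound 3, both modest and both downward; the new group lacks the hydrogen-bond donor that compound 3 carries, as do compounds 1 and 2. The step from compound 3 to compound 4 is therefore expected to run upward, modestly, of roughly the size seen in a number 18 percentage points lower from compound 2 to compound 3 (beyond the scatter) reversed, namely a number 19 percentage points higher from compound 3 to compound 4 (beyond the scatter). Compound 4 is accordingly estimated at 20%, with a range from 5% to 35%.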

Compound 4, a percentage reported as inhibition, at one concentration (the size of the read-out at that concentration, not a potency): 1%
Beside the measured number, compound 4's estimate is 19 percentage points above it; measured number outside the range, below it.
By their numbers in this assay, from the lowest: compounds 3 and 4 (each within the scatter of the next); then compounds 2 and 1 (each within the scatter of the next).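

Taking away the hydrogen-bond donor of the ethylamino group did not lift the number in this assay (no change at the digits printed from compound 3 to compound 4 (within the scatter)). The presence of that donor therefore does not by itself separate compound 3 from compounds 1 and 2, since compound 4 also has no donor in this group and still falls short of both (a number 18 percentage points lower from compound 2 to compound 4 (beyond the scatter); a number 25 percentage points lower from compound 1 to compound 4 (beyond the scatter)). No measurement shown gives a reason why isopropylsulfanyl on this carbonyl carbon behaves this way.

As far as these compounds go, it remains open whether the sulfur or the shape of the chain sets compound 4 apart from compounds 1 and 2. Isopropoxy or tert-butylsulfanyl on the same carbonyl carbon would separate these two differences.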